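A few compounds are considered here, and "the series" means these few. Any claim that something is new, unique, unknown or untested is made for them only; others in the source may bear on it.

Measured so far:
- Compound 1 `COc1cnc(C[S+]([O-])c2nc3cc(OC(F)F)ccc3[nH]2)cc1OC`: 0.283 h
- Compound 2 `COc1ccnc(C[S+]([O-])c2nc3cc(OC(F)F)ccc3[nH]2)c1`: 0.117 h

In an ADME assay, at pH 3 (on this read-out higher numbers stand for a longer-lived compound and lower numbers for a shorter-lived compound), compound 1 holds the higher of the two numbers. Among the measured compounds shown here, the only measured step is a 2.4-fold lower number from compound 1 to compound 2 (0.38 log units; beyond the scatter), a modest one in which hydrogen replaces methoxy on an aromatic carbon.

Compound 3 `COc1cnc(C[S+]([O-])c2nc3cc(OC(F)(F)C(F)F)ccc3[nH]2)cc1OC` has not been measured yet. It keeps both methoxy groups of compound 1 and changes elsewhere: difluoromethyl in place of hydrogen on a saturated chain carbon bound to two fluorine atoms and an oxygen on an aromatic ring. Difluoromethoxy thus becomes 1,1,2,2-tetrafluoroethoxy. For the measured compounds named here, no measured step changes this group, so the step to compound 2 serves only as a rough guide to size. A change in this assay no larger than that modest step is expected, and most likely none beyond the scatter. The expected step is a 1.1-fold higher number from compound 1 to compound 3 (0.03 log units; within the scatter). For compound 3 the estimate is 0.3 h, with an expected range from 0.16 h to 0.55 h.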

Compound 3, half-life: 0.317 h
Estimate against measurement, compound 3: 1.1-fold (0.02 log units) below; low and high end bracket the measured number.
By their numbers in this assay, from the lowest: compound 2; then compounds 1 and 3 (each within the scatter of the next).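

Extending difluoromethoxy to 1,1,2,2-tetrafluoroethoxy gives a 1.1-fold higher number from compound 1 to compound 3 (0.05 log units; within the scatter) in this assay, so this read-out does not separate the two compounds. Among the compounds shown here, this is the first measured change at this end of the molecule, and adding difluoromethyl on the saturated chain carbon leaves no step beyond the scatter, unlike the earlier swap of methoxy for hydrogen. Nothing available gives a reason for this result.

Still open, on these data alone, is how this assay would read with a non-fluorinated group here, such as a plain ethoxy, a longer chain, an amine or a carboxylic acid. Also open, as far as these compounds go, is whether the same extension would read alike on the core of compound 2, which carries one methoxy group fewer.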